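A few compounds are considered here, and "the series" means these few. Any claim that something is new, unique, unknown or untested is made for them only; others in the source may bear on it.

Compound 1 `C=C1C(=O)O[C@@H]2CC(C)=C([C@@H](C)CCCOC(C)=O)[C@@H](OC(=O)CCl)[C@H]12`, compound 2 `C=C1C(=O)O[C@@H]2CC(C)=C([C@@H](C)CCCOC(C)=O)[C@@H](OC(=O)CN3CCCC3)[C@H]12` and compound 3 `C=C1C(=O)O[C@@H]2CC(C)=C([C@@H](C)CCCOC(C)=O)[C@@H](OC(=O)COc3ccc(C(C)=O)cc3)[C@H]12` share one core and differ only in the group on a saturated chain carbon bound to a carbonyl carbon. In a functional assay on HCT-116 cells (Homo sapiens) for cytotoxicity, read by sulforhodamine B assay, with a stated time of 72 h (a lower number here means a stronger inhibitor, a higher number a weaker inhibitor), compound 1 gives 18800 nM, compound 2 gives 20500 nM and compound 3 gives 40100 nM. Compound 3 holds the highest number of the three, but a 2.0-fold higher number from compound 2 to compound 3 (0.29 log units; within the scatter) stays within the scatter, and only a 2.1-fold higher number from compound 1 to compound 3 (0.33 log units; beyond the scatter) goes modestly beyond it. Compound 4 `C=C1C(=O)O[C@@H]2CC(C)=C([C@@H](C)CCCOC(C)=O)[C@@H](OC(=O)COc3ccc4c(CC)noc4c3)[C@H]12` carries a group of 11 heavy atoms (9 carbon, 1 nitrogen, 1 oxygen; one five-membered aromatic ring with 2 hetero atoms, one six-membered aromatic ring of carbon only) in place of a group of 9 heavy atoms (8 carbon, 1 oxygen; one six-membered aromatic ring of carbon only), on an oxygen on a saturated carbon. For the measured compounds named here, no measured step touches this position; the steps of a 1.1-fold higher number from compound 1 to compound 2 (0.04 log units; within the scatter) and a 2.1-fold higher number from compound 1 to compound 3 (0.33 log units; beyond the scatter) show that varying the group on that chain carbon moves this assay little. Compound 4 is therefore expected to show a 1.0-fold lower number from compound 3 to compound 4 (0.00 log units; within the scatter), giving an estimated 40000 nM within 15000 nM to 100000 nM.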

Compound 4, half-maximal inhibitory concentration: 18300 nM
The estimate for compound 4 lay 2.2-fold (0.34 log units) above the measured number; the measured number falls inside the stated range.
By their numbers in this assay, from the lowest: compounds 4, 1, 2 and 3 (each within the scatter of the next, the first and the last beyond it).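

Putting the two-ring group on the oxygen on a saturated carbon in place of 4-acetylphenyl gives a 2.2-fold lower number from compound 3 to compound 4 (0.34 log units; beyond the scatter) in this assay, so a change at this place can shift the number modestly. That shift brings no gain over the simpler groups on the chain carbon, as a 1.1-fold lower number from compound 2 to compound 4 (0.05 log units; within the scatter) and a 1.0-fold lower number from compound 1 to compound 4 (0.01 log units; within the scatter) both stay within the scatter. Nothing available here explains the shift. As far as these compounds go, whether an amine or a carboxylic acid in place of the group on that oxygen would take the number in this assay clearly below that of compound 1 remains open.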